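Fluoro for Methoxy on the Amide Aryl Ring

A few compounds are considered here, and "the series" means these few. Any claim that something is new, unique, unknown or untested is made for them only; others in the source may bear on it.

compound 1 `O=C(Nc1ccccc1Cl)c1ccc(/N=N\c2c[nH]c3ccccc23)cc1` — in a functional assay on MCF7 cells (Homo sapiens) for inhibition, read by MTT assay, with a stated time of 72 h (a higher number here means a weaker inhibitor, a lower number a stronger inhibitor), compound 1 gives 112000 nM
compound 2 `O=C(Nc1cccc(Cl)c1)c1ccc(/N=N\c2c[nH]c3ccccc23)cc1` — in this assay compound 2 gives 82700 nM
compound 3 `COc1ccccc1NC(=O)c1ccc(/N=N\c2c[nH]c3ccccc23)cc1` — in this assay compound 3 gives 86500 nM

On these numbers compound 3 stands second of the three, with compound 2 nearest: a 1.0-fold higher number from compound 2 to compound 3 (0.02 log units; within the scatter). Its distance from compound 1 is also small: a 1.3-fold lower number from compound 1 to compound 3 (0.11 log units; within the scatter). Compound 4 `O=C(Nc1ccccc1F)c1ccc(/N=N\c2c[nH]c3ccccc23)cc1` has not yet been measured. It differs from compound 3 in one place: fluoro in place of methoxy on an aromatic carbon. The step that bears most on this change is the one at the same position, a 1.3-fold lower number from compound 1 to compound 3 (0.11 log units; within the scatter), which stayed within the scatter; the other two steps, a 1.4-fold lower number from compound 1 to compound 2 (0.13 log units; within the scatter) and a 1.0-fold higher number from compound 2 to compound 3 (0.02 log units; within the scatter), were also within it. No step beyond the scatter is therefore expected in this assay for compound 4, in either direction. Compound 4 is estimated at 95000 nM, with a range from 45000 nM to 200000 nM, which means an expected step of a 1.1-fold higher number from compound 3 to compound 4 (0.04 log units; within the scatter).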

Compound 4, half-maximal inhibitory concentration: 83800 nM
Compound 4: the middle estimate sits 1.1-fold (0.05 log units) above what was measured; the range from low to high includes it.
By their numbers in this assay, from the lowest: compounds 2, 4, 3 and 1 (each within the scatter of the next).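

In this assay fluoro in place of methoxy at this position, on an aromatic carbon ortho to a large group, stays within the scatter (a 1.0-fold lower number from compound 3 to compound 4 (0.01 log units; within the scatter)). The same holds for fluoro in place of chloro (a 1.3-fold lower number from compound 1 to compound 4 (0.13 log units; within the scatter)) and for 2-fluorophenyl in place of 3-chlorophenyl (a 1.0-fold higher number from compound 2 to compound 4 (0.01 log units; within the scatter)), so compound 4 cannot be told apart from the other three compounds here.

As far as these compounds go, whether an amine, a carboxylic acid or a longer chain on this ring would give a step beyond the scatter remains open. No evidence is available on why these groups read alike.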